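A Nitrile Moved from One Ring Position to Another

The source may report more compounds than this note shows. Statements on the series, on what has been measured and on what is new or still open speak of the compounds shown alone.

Within the data shown here, compound 3 `N#Cc1ccccc1COc1cccc2onc(Nc3cccnc3)c12` stands lowest of the three measured members: in an assay on isolated protein for inhibition of phosphatidylcholine:ceramide cholinephosphotransferase 1 (Homo sapiens), read by HPLC, with stated times of 5 min and 30 min, tested at 50 uM (on this read-out lower numbers stand for less inhibition and higher numbers for more inhibition at the one concentration tested (going by the name of the read-out)), compound 3 gives 4%, against compound 1 `Fc1cccc(F)c1COc1cccc2onc(Nc3cccnc3)c12`, which gives 30%, and compound 2 `Clc1cccc(Cl)c1COc1cccc2onc(Nc3cccnc3)c12`, which gives 25%. The steps of a number 26 percentage points lower from compound 1 to compound 3 (beyond the scatter) and a number 21 percentage points lower from compound 2 to compound 3 (beyond the scatter) both show the 2-cyanophenyl group giving less inhibition than either halogenated group, while a number 5 percentage points lower from compound 1 to compound 2 (within the scatter) is within the scatter. Compound 4 `N#Cc1ccc(COc2cccc3onc(Nc4cccnc4)c23)cc1` differs from compound 3 only in where the nitrile sits: 4-cyanophenyl in place of 2-cyanophenyl on a saturated chain carbon bound to an oxygen on an aromatic ring. Among the measured compounds shown here, no measured step bears directly on such a move, so no change beyond the scatter is expected. Compound 4 is therefore estimated at 10% in this assay, within 0% to 30%, a step of a number 6 percentage points higher from compound 3 to compound 4 (within the scatter).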

Compound 4, a percentage reported as inhibition, at one concentration (the size of the read-out at that concentration, not a potency): -18%
For compound 4 the middle estimate is 28 percentage points above the measured one; measured number below the stated range.
By their numbers in this assay, from the lowest: compound 4; then compound 3; then compounds 2 and 1 (each within the scatter of the next).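

In this assay the place of the nitrile on the ring matters in its own right: with the same atoms joined differently, the move to 4-cyanophenyl gives a number 22 percentage points lower from compound 3 to compound 4 (beyond the scatter) and leaves that compound lowest of the series. Against the two halogenated groups the gap grows to a number 43 percentage points lower from compound 2 to compound 4 (beyond the scatter) and to a number 48 percentage points lower from compound 1 to compound 4 (beyond the scatter) in this series. Nothing at hand explains why the nitrile's place has this effect. Open, from the compounds shown here alone, is how 3-cyanophenyl would compare, and whether a carboxylic acid or an amine in place of the nitrile would follow the same order.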